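Demethylation of the methoxy group: compound 3 to compound 4

The compounds below may be only part of what the source reports. "The series", "measured", "known", "first", "only" and "open" are said of these compounds alone.

Measured so far:
- Compound 1, `COc1cc(C)cc(-c2nn(CC#N)cc2-c2ccc(-c3cccc(C(C)=O)c3)nc2)c1`, gives 88% in a functional assay on OVCAR-8 cells (Homo sapiens) for cytotoxicity, read by sulforhodamine B assay, with a stated time of 48 h, tested at 0.01 uM; a higher number here means a weaker effect of the compound at the concentration tested, a lower number a stronger effect.
- Compound 2, `Cc1cc(O)cc(-c2nn(CC#N)cc2-c2ccnc(-c3ccc(Oc4ccccc4)cc3)c2)c1`, gives 91% in this assay.
- Compound 3, `COc1cc(C)cc(-c2nn(CC#N)cc2-c2ccnc(-c3ccc(N(C)C)cc3)c2)c1`, gives 97% in this assay.

All three numbers sit close together, and at this concentration none of the compounds shows more than a small effect. Compound 3 lies within the scatter of compound 2 and also within the scatter of compound 1, so no order among the three can be read from this assay.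

The next compound, compound 4, `Cc1cc(O)cc(-c2nn(CC#N)cc2-c2ccnc(-c3ccc(N(C)C)cc3)c2)c1`, differs from compound 3 in one place: hydrogen in place of methyl on an oxygen on an aromatic ring. The same exchange of methoxy for hydroxy is already present between compound 1 and compound 2 on their shared aryl ring, though those two also differ elsewhere, and both give numbers within the scatter of compound 3.

On this basis no step beyond the scatter is expected in this assay from compound 3 to compound 4; the expected step is a number 4 percentage points lower from compound 3 to compound 4 (within the scatter). Compound 4 is therefore estimated at 93%, with a range from 82% to 100%.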

Compound 4, a percentage reported as activity, at one concentration (the size of the read-out at that concentration, not a potency): 97%
Compound 4: the middle estimate sits 4 percentage points below what was measured; the range from low to high includes it.
By their numbers in this assay, from the lowest: compounds 1, 2, 3 and 4 (each within the scatter of the next).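

In this assay the exchange of methoxy for hydroxy on the 3-methoxy-5-methylphenyl ring can now be read on its own, without a second difference elsewhere in the molecule: hydrogen in place of methyl on this oxygen gives no change at the digits printed from compound 3 to compound 4 (within the scatter) and so leaves the read-out unmoved at this concentration. With hydroxy held fixed, the second one-place pair isolates the other aryl substituent, and dimethylamino in place of phenoxy on an aromatic carbon gives a number 6 percentage points higher from compound 2 to compound 4 (within the scatter), so this site also shows no step beyond the scatter. Nothing measured on these compounds offers an explanation for either result.

The compounds shown leave open whether methoxy and hydroxy would separate under conditions where the compounds have a larger effect, since a single low concentration with numbers this close cannot show any difference hidden within the scatter. Also open, as far as these compounds go, is whether, in this assay, an ethoxy group on this oxygen, or a primary amine or a carboxylic acid in place of dimethylamino, would give a number beyond the scatter of compound 4.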